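The compounds below may be only part of what the source reports. "The series", "measured", "known", "first", "only" and "open" are said of these compounds alone.

In a functional assay on MCF7 cells (Homo sapiens) for cytotoxicity, read by MTT assay, with a stated time of 72 h (a higher number here means a weaker inhibitor, a lower number a stronger inhibitor), compound 1 `O=C(N/N=C/c1ccc([N+](=O)[O-])cc1)Nc1cc2c(Nc3ccc(F)c(Cl)c3)ncnc2cc1O[C@H]1CCOC1` is recorded as "not active" (no number reported), with no number reported. Compound 2 `COc1ccc(/C=N/NC(=O)Nc2cc3c(Nc4ccc(F)c(Cl)c4)ncnc3cc2O[C@H]2CCOC2)cc1` gives 27300 nM. Compound 3 `COc1cc2ncnc(Nc3ccc(F)c(Cl)c3)c2cc1NC(=O)N/N=C/c1ccc([N+](=O)[O-])cc1` gives 36800 nM, and this value lies within the scatter of compound 2, so the two numbers cannot be separated.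

Compound 4 `COc1cc2ncnc(Nc3ccc(F)c(Cl)c3)c2cc1NC(=O)N/N=C/c1cc(Br)c(O)c(Br)c1` is reached from compound 3 by a single change: 3,5-dibromo-4-hydroxyphenyl in place of 4-nitrophenyl on a carbon with a double bond to nitrogen. In words, 3,5-dibromo-4-hydroxyphenyl stands in place of 4-nitrophenyl on a carbon with a double bond to nitrogen.

Among the compounds with values here, no two measured compounds differ in one place only, so the series offers no direct measure of a step of this kind. The expectation therefore starts from compound 3 at 36800 nM, with a modest move toward a lower number in this assay and a real chance of none beyond the scatter. The estimated change is a 1.8-fold lower number from compound 3 to compound 4 (0.26 log units; within the scatter). This remains a weakly supported expectation, and a result without a number cannot be ruled out. For compound 4 the expected value is 20000 nM, with an estimated range of 6000 nM to 60000 nM.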

Compound 4, half-maximal inhibitory concentration: 30200 nM
Compound 4: the middle estimate sits 1.5-fold (0.18 log units) below what was measured; the range from low to high includes it.
By their numbers in this assay, from the lowest: compounds 2, 4 and 3 (each within the scatter of the next).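

In this assay, the first step read at a single place in the series is a 1.2-fold lower number from compound 3 to compound 4 (0.09 log units; within the scatter). At this position, on a carbon with a double bond to nitrogen, 3,5-dibromo-4-hydroxyphenyl therefore cannot be separated from 4-nitrophenyl, even though the exchange removes the nitro group and brings in bromine and a hydrogen-bond donor. No measurement shown bears on the reason for this result.

Whether any group at this position can move the number beyond the scatter remains open, since the compounds shown carry only substituted phenyl groups there and none with an amine or a carboxylic acid on the ring. Compound 1 has no number, so steps involving it cannot be read.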